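The compounds below may be only part of what the source reports. "The series", "measured", "known", "first", "only" and "open" are said of these compounds alone.

Three compounds of the series have so far been run in a functional assay on EL4 cells (Mus musculus) for inhibition, tested at 100 uM; on this read-out higher numbers stand for more inhibition at the one concentration tested (going by the name of the read-out) and lower numbers for less inhibition. Compound 2 `OC[C@H]1O[C@@H](n2cnc3c(Cl)nccc32)C[C@@H]1O` gives < 5%, which is a limit of the assay and not a number. Compound 1 `CN(C)c1nccc2c1ncn2[C@H]1C[C@H](O)[C@@H](CO)O1` is compound 2 carrying the change (dimethylamino in place of chloro on an aromatic carbon), and in this assay compound 1 also gives < 5%, again a limit. The step that the two limits leave unreadable from compound 2 to compound 1 is therefore not readable, because both ends sit at the limit of < 5% in this assay, at which 3 of the 3 values shown sit. Compound 3 `OC[C@H]1OC(n2cnc3c(Cl)nccc32)[C@H](O)[C@@H]1O` gives < 5% in this assay, a limit as well. The difference between the core of compound 3 and the core of compound 2 is not broken down here. Compound 4 `CN(C)c1nccc2c1ncn2C1O[C@H](CO)[C@@H](O)[C@H]1O` is compound 3 carrying the same change, (dimethylamino in place of chloro on an aromatic carbon), and awaits measurement in this assay. The expected step is a step that the limit leaves unreadable from compound 3 to compound 4, since a step that the two limits leave unreadable from compound 2 to compound 1 is unreadable and all three values sit at the limit of < 5% in this assay, at which 3 of the 3 values shown sit. Compound 4 is estimated at 3%, most likely reported as a limit once more.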

Compound 4, a percentage reported as inhibition, at one concentration (the size of the read-out at that concentration, not a potency): 10%
Beside the measured number, compound 4's estimate is 7 percentage points below it, and the stated range covers the measured number.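

In this assay, dimethylamino in place of chloro on an aromatic carbon gives a number at least 5 percentage points higher from compound 3 to compound 4 (that floor lies within the scatter). The same change on the core of compound 2 cannot be read, because both of its ends are limits: the limit of < 5% in this assay, at which 3 of the 4 values shown sit. The change is therefore neither shown to carry from one core to the other nor shown to depend on the core, and the printed floor of the one readable step does not establish a rise beyond the scatter.

Open, going by these compounds, is whether a primary amine or an amine with longer chains on the same aromatic carbon would give a readable value on either core. Also open, on these data alone, is whether any such group would separate the two cores in this assay.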